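Chain Length of the Acid Arm in Platelet Inhibitors

The source may report more compounds than this note shows. Statements on the series, on what has been measured and on what is new or still open speak of the compounds shown alone.

Of the compounds shown here, three have been measured in a functional assay on a cell-free system (Platelet, plasma, Homo sapiens) for inhibition; a lower number here means a stronger inhibitor, a higher number a weaker inhibitor. Compound 1 `O=C(O)CCN1Cc2ccc(NC(=O)c3ccc4c(c3)CNCC4)cc2C1=O` gives 1100 nM in this assay. Compound 2 `O=C(O)CCCN1Cc2ccc(NC(=O)c3ccc4c(c3)CNCC4)cc2C1=O` gives 330000 nM. Compound 3 `O=C(O)CN1Cc2ccc(NC(=O)CC3CCNCC3)cc2C1=O`, built on a different core, gives 51000 nM.

The move from compound 1 to compound 2 is a single change, (carboxymethyl in place of carboxy on a saturated chain carbon, two bonds along the chain from an amide-type nitrogen in a ring), and it made the step of a 300-fold higher number from compound 1 to compound 2 (2.48 log units; beyond the scatter). The difference between the cores of compound 1 and compound 3 is not broken down here.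

Compound 4 `O=C(O)CCN1Cc2ccc(NC(=O)CC3CCNCC3)cc2C1=O` is not yet measured. It arises from compound 3 by carboxymethyl in place of carboxy on a saturated chain carbon bound to an amide-type nitrogen in a ring. Among the compounds with values here, this is the same kind of change as the one from compound 1 to compound 2, though not the same: there the place was two bonds along the chain from the amide-type nitrogen in a ring, here it is bound to that nitrogen. After the change, compound 4 carries a 2-carboxyethyl chain, the chain that compound 1 also carries.

Because compound 1 gives the lowest number, 1100 nM, with exactly that chain length, the step in this assay from compound 3 to compound 4 is expected to be a lowering, a 10-fold lower number from compound 3 to compound 4 (1.01 log units; beyond the scatter). The large loss seen in a 300-fold higher number from compound 1 to compound 2 (2.48 log units; beyond the scatter) shows that chain length moves this assay strongly, so the uncertainty is wide. Compound 4 is estimated at 5000 nM, with a likely range from 800 nM to 40000 nM.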

Compound 4, half-maximal inhibitory concentration: 7400 nM
The estimate for compound 4 lay 1.5-fold (0.17 log units) below the measured number; low and high end bracket the measured number.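

In this assay, the new change gives a 6.9-fold lower number from compound 3 to compound 4 (0.84 log units; beyond the scatter), so swapping carboxy for carboxymethyl lowers the number on this core, whereas on the core of compound 1 it raises it, and the two results clearly differ: the same change on two cores in this assay, a 300-fold higher number (2.48 log units; beyond the scatter) from compound 1 to compound 2 and a 6.9-fold lower number (0.84 log units; beyond the scatter) from compound 3 to compound 4, 2100-fold (3.32 log units) apart, beyond the scatter of two such steps

The size and even the direction of this change therefore do not carry from one core to the other, although both pairs agree on a narrower point: within each pair, the compound with the 2-carboxyethyl chain, compound 1 or compound 4, gives the lower number. This does not show that the core alone causes the reversal, since the two steps also differ in place, one on a saturated chain carbon bound to the amide-type nitrogen in a ring and the other two bonds along the chain from it, and two pairs cannot establish a rule for the series.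

The compounds shown leave open how the carboxymethyl chain behaves on the core of compound 1, and how the longer chain of compound 2 behaves on the core of compound 3. They also leave open whether the carboxylic acid itself could give way to a methyl ester on either core.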